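A few compounds are considered here, and "the series" means these few. Any claim that something is new, unique, unknown or untested is made for them only; others in the source may bear on it.

Measured compounds in a functional assay on HeLa cells (Homo sapiens) for antiproliferative activity, with a stated time of 24 h; a lower number here means a stronger inhibitor, a higher number a weaker inhibitor:
compound 1 `NC(=O)c1c(NC(=O)c2ccccc2Cl)sc2c1CCN(Cc1ccccc1)C2` gives 38400 nM;
compound 2 `NC(=O)c1c(NC(=O)c2ccccc2Cl)sc2c1CCN(Cc1cc(Cl)cc(Cl)c1)C2` gives 19600 nM;
compound 3 `COc1ccccc1NC(=S)N1CCc2c(sc(NC(=O)c3ccccc3Cl)c2C(N)=O)C1` gives only a limit of the assay, > 50000 nM.

Compound 3 therefore has no number of its own in this assay, only a limit (the limit of > 50000 nM in this assay, at which 1 of the 3 values shown sits). Compared with the other two, it sits at the far end: the step of an at least 1.3-fold higher number from compound 1 to compound 3 (0.11 log units; that floor lies within the scatter) stays within the scatter, so compound 3 cannot be ordered against compound 1, while the step of an at least 2.5-fold higher number from compound 2 to compound 3 (0.40 log units; beyond the scatter) lies beyond it, so compound 3 is a weaker inhibitor than compound 2.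

Compound 4 `NC(=O)c1c(NC(=O)c2ccccc2Cl)sc2c1CCN(C(=S)Nc1cccnc1)C2` differs from compound 3 in one place: pyridin-3-yl in place of 2-methoxyphenyl on an amide-type nitrogen. Among the measured compounds shown here, none of the measured steps touches this part of the molecule; all three change the group on the amine nitrogen in the ring, and the two that bring in the thiocarbonyl arm, an at least 1.3-fold higher number from compound 1 to compound 3 (0.11 log units; that floor lies within the scatter) and an at least 2.5-fold higher number from compound 2 to compound 3 (0.40 log units; beyond the scatter), end at the limit. There is thus no measured guide for swapping one aromatic ring for another on the thiocarbonyl nitrogen, and the step from compound 3 to compound 4 is expected to be a step that the limit leaves unreadable from compound 3 to compound 4, nothing beyond the scatter. Compound 4 is accordingly estimated at 60000 nM, with a range from 25000 nM to 150000 nM, and most likely again reported only as a limit.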

Compound 4, half-maximal inhibitory concentration: > 50000 nM
Compound 4: only a limit was reported; the forecaster's own chance of this, stated with the estimate: 70%; the middle value is on the limit's open side.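

In this assay, compound 4, with pyridin-3-yl in place of 2-methoxyphenyl on the amide-type nitrogen, sits at the same limit as compound 3, so the step between them cannot be read: the limit of > 50000 nM in this assay, at which 2 of the 4 values shown sit.

The thiocarbonyl arm thus stays at the limit with either aromatic ring on that nitrogen, one of carbon only and one with a hetero atom. On the amine nitrogen in the ring, an at least 2.5-fold higher number from compound 2 to compound 4 (0.40 log units; beyond the scatter) marks a loss against the 3,5-dichlorophenyl group, whereas an at least 1.3-fold higher number from compound 1 to compound 4 (0.11 log units; that floor lies within the scatter) gives no order against the phenyl group.

The compounds shown leave open whether any group on the thiocarbonyl nitrogen would bring a readable number in this assay. An ethyl chain or a cyclohexyl ring there could test whether an aromatic ring matters at all.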